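Thiophene sulfonamide series: pyridinylmethyl replacing the branched chain

This account rests on a few compounds, and the source may have more. Where it says the series, first, only, none or still open, it means among the compounds named here.

Measured so far in an ADME assay on Huh-7 cells (Homo sapiens) for cytotoxicity, with a stated time of 72 h; a lower number here means that less compound is tolerated, a higher number that more compound is tolerated:
- Compound 1, `CCS(=O)(=O)Nc1ccc2c(c1)S(=O)(=O)N=C(c1c(O)c(-c3cccs3)nn(CCC(C)C)c1=O)N2`, gives > 33000 nM in this assay, a limit of the assay.
- Compound 2, `COCN(c1ccc2c(c1)S(=O)(=O)N=C(c1c(O)c(-c3cccs3)nn(CCC(C)C)c1=O)N2)S(C)(=O)=O`, gives > 1000 nM in this assay, a limit of the assay.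
- Compound 3, `CCC(C)(C)Cn1nc(-c2cccs2)c(O)c(C2=NS(=O)(=O)c3cc(NS(C)(=O)=O)ccc3N2)c1=O`, gives > 1000 nM in this assay, a limit of the assay.

Among the measured compounds shown here, compound 3 stands at a limit, as do the two other values shown, so no compound in the set has a number in this assay. For the measured compounds named here, the one step between measured neighbours, a step that the two limits leave unreadable from compound 1 to compound 2, is not readable, the two ends being the limit of > 33000 nM in this assay, at which 1 of the 3 values shown sits, and (the limit of > 1000 nM in this assay, at which 2 of the 3 values shown sit).

Compound 4, `CS(=O)(=O)Nc1ccc2c(c1)S(=O)(=O)N=C(c1c(O)c(-c3cccs3)nn(Cc3ccccn3)c1=O)N2`, differs from compound 3 by pyridin-2-yl in place of 1,1-dimethylpropyl on a saturated chain carbon bound to an aromatic nitrogen. Going by the values given here, no measured step carries this change, and the only evidence on the measured step is the pair of limits. No direction can therefore be read from the data, and compound 4 is expected to sit where compound 3 sits, that is at a limit rather than a number.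

Estimate for compound 4 in this assay: 20000 nM, with a range from 3000 nM to 60000 nM, which as a step means a step that the limit leaves unreadable from compound 3 to compound 4 expected from compound 3.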

Compound 4, half-maximal cytotoxic concentration: > 1000 nM
Compound 4 gave a limit, no number (the forecaster's own chance of this, stated with the estimate: 75%); the middle value is on the limit's open side.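

Compound 3 and compound 4 both stand at limits of the assay, so the step between them, pyridin-2-yl in place of 1,1-dimethylpropyl, cannot be read. The compounds shown leave open whether this change has any effect in this assay; none of the four has a number.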